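The compounds below may be only part of what the source reports. "The series", "measured", "known", "first", "only" and "open" are said of these compounds alone.

Measured so far:
Compound 1, `COc1cc(Cl)cc(-c2nn(-c3cccc(NC(=O)c4ccc(Cl)c(Cl)c4)c3)cc2-c2ccncc2)c1`: 78.4%
Compound 2, `O=C(Nc1cccc(-n2cc(-c3ccncc3)c(-c3cc(O)cc(Cl)c3)n2)c1)Nc1ccc(Cl)c(C(F)(F)F)c1`: -38%

In a functional assay on SK-MEL-2 cells (Homo sapiens) for inhibition, read by sulforhodamine B assay, with a stated time of 48 h, tested at 10 uM (a higher number here means a weaker effect of the compound at the concentration tested, a lower number a stronger effect), compound 2 gives -38%, the lowest of the two numbers and so the stronger effect at the concentration tested. Going by the values given here, compound 1 gives 78.4% in this assay, a gap far beyond the scatter; compound 1 also differs from compound 2 in more than one place, so the two values show only that compound 1 is much weaker here than compound 2.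

Compound 3, `COc1cc(Cl)cc(-c2nn(-c3cccc(NC(=O)Nc4ccc(Cl)c(C(F)(F)F)c4)c3)cc2-c2ccncc2)c1`, has not yet been measured in this assay. It is made from compound 2 by a single change: methyl in place of hydrogen on an oxygen on an aromatic ring. Among the compounds with values here, no step between two measured compounds isolates this change, so the expectation rests on two things: a change of this small size often moves a read-out of this kind only moderately, while compound 1, which also carries the methoxy group, gives 78.4% and leaves room for a larger loss. Compound 3 is therefore expected to lose some effect, with the step of a number 53 percentage points higher from compound 2 to compound 3 (beyond the scatter) going upward. The estimate for compound 3 in this assay is 15%, expected to lie between -35% and 70%.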

Compound 3, a percentage reported as activity, at one concentration (the size of the read-out at that concentration, not a potency): -34%
For compound 3 the middle estimate is 49 percentage points above the measured one; the range from low to high includes it.
By their numbers in this assay, from the lowest: compounds 2 and 3 (each within the scatter of the next); then compound 1.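

In this assay, methyl in place of hydrogen on an oxygen on an aromatic ring, which turns hydroxy into methoxy, gives a number 4 percentage points higher from compound 2 to compound 3 (within the scatter), so this single change leaves the read-out unchanged within normal variation. The large gap seen earlier therefore traces to a different place in the structure: with the methoxy group held constant, (4-chloro-3-(trifluoromethyl)phenyl)amino in place of 3,4-dichlorophenyl on a carbonyl carbon gives a number 112.4 percentage points lower from compound 1 to compound 3 (beyond the scatter). No measurement here explains either step.

The compounds shown compare only hydroxy and methoxy on this aromatic ring, so it stays open whether a longer chain such as ethoxy, or an amine in place of the oxygen, would keep the effect. The change on the carbonyl carbon is also read only with methoxy present, leaving open whether it would have a similar size with hydroxy or another group at that place.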